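Swapping chlorophenyl for hydroxyphenyl in compound 3

The source may report more compounds than this note shows. Statements on the series, on what has been measured and on what is new or still open speak of the compounds shown alone.

Compound 2 `C/C(=N\NC(=O)COc1cccc2ccccc12)c1ccc(Cl)cc1` was tested in an ADME assay on HEL cells (Homo sapiens) for cytotoxicity (a lower number here means that less compound is tolerated, a higher number that more compound is tolerated), where compound 2 gives 7.1 ug/mL. Compound 1 `C/C(=N\NC(=O)COc1cccc2ccccc12)c1ccc(O)cc1` gives 11.1 ug/mL in this assay, and compound 2 stands with it inside the usual scatter: a 1.6-fold lower number from compound 1 to compound 2 (0.19 log units; within the scatter). Compound 3 `C/C(=N\NC(=O)COc1cccc2ccccc12)c1ccccc1O` has not been measured; it differs from compound 2 in that (2-hydroxyphenyl in place of 4-chlorophenyl on a carbon with a double bond to nitrogen). Within the data shown here, the only measured step that bears on this change, a 1.6-fold lower number from compound 1 to compound 2 (0.19 log units; within the scatter), exchanged a hydroxy and a chloro group in the opposite direction and stayed within the scatter, so no step beyond the scatter is expected for compound 3: a 1.4-fold higher number from compound 2 to compound 3 (0.15 log units; within the scatter). Compound 3 is therefore estimated at 10 ug/mL, with a range from 5 ug/mL to 20 ug/mL.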

Compound 3, half-maximal cytotoxic concentration: 4 ug/mL
For compound 3 the middle estimate is 2.5-fold (0.40 log units) above the measured one; the whole stated range lies above it.
By their numbers in this assay, from the lowest: compounds 3, 2 and 1 (each within the scatter of the next, the first and the last beyond it).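

In this assay, the place of the hydroxy group on the ring now shows a step that the earlier exchange of hydroxy for chloro did not: 2-hydroxyphenyl in place of 4-hydroxyphenyl gives a modest change (a 2.8-fold lower number from compound 1 to compound 3 (0.44 log units; beyond the scatter)). Set against 4-chlorophenyl, the same 2-hydroxyphenyl stays inside the scatter (a 1.8-fold lower number from compound 2 to compound 3 (0.25 log units; within the scatter)). Nothing available gives a reason for this difference. The compounds shown leave open whether an amine or a carboxylic acid on this ring would give a number nearer compound 1 or compound 3.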